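The source may report more compounds than this note shows. Statements on the series, on what has been measured and on what is new or still open speak of the compounds shown alone.

- compound 1 `CCOC(=O)NC(=O)NC1=CS(=O)(=O)O[C@@]12[C@@H](CO[Si](C)(C)C(C)(C)C)O[C@@H](n1cc(C)c(=O)n(C)c1=O)[C@@H]2O[Si](C)(C)C(C)(C)C`: 3000 nM
- compound 2 `Cc1cn([C@@H]2O[C@H](CO[Si](C)(C)C(C)(C)C)[C@@]3(OS(=O)(=O)C=C3NCC(=O)C(=O)O)[C@H]2O[Si](C)(C)C(C)(C)C)c(=O)n(C)c1=O`: 72600 nM

Both values come from a functional assay on CCRF-CEM cells (Homo sapiens); on this read-out lower numbers stand for higher toxicity in this test and higher numbers for lower toxicity in this test. Of the two, compound 2 has the higher number at 72600 nM, so it is the less toxic in this assay.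

Compound 3 `Cc1cn([C@@H]2O[C@H](CO[Si](C)(C)C(C)(C)C)[C@@]3(OS(=O)(=O)C=C3NCC(=O)C(N)=O)[C@H]2O[Si](C)(C)C(C)(C)C)c(=O)n(C)c1=O` is not yet measured. It differs from compound 2 in one place: amino in place of hydroxy on a carbonyl carbon. In words, this is amino in place of hydroxy on a carbonyl carbon, which turns carboxy into carbamoyl.

Among the measured compounds shown here, only one measured step offers any guidance: a 24-fold higher number from compound 1 to compound 2 (1.38 log units; beyond the scatter). That large step came with a different swap, (carboxycarbonyl)methyl in place of (ethoxycarbonyl)carbamoyl on an amine nitrogen. For the measured compounds named here, it is therefore a loose guide, and no measured pair shows the swap of hydroxy for amino itself.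

Compound 2 sits at the top of the two numbers, so a modest move downward seems more likely than a further rise, though this is a weak inference from little data. The expected change is a 2.9-fold lower number from compound 2 to compound 3 (0.46 log units; beyond the scatter), smaller than the measured step.

For compound 3 the estimated value is 25000 nM, with an expected range of 5000 nM to 100000 nM.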

Compound 3, half-maximal cytotoxic concentration: 9960 nM
The estimate for compound 3 lay 2.5-fold (0.40 log units) above the measured number; low and high end bracket the measured number.
By their numbers in this assay, from the lowest: compound 1; then compound 3; then compound 2.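

In this assay, a carbonyl carbon whose other neighbour is a carbonyl carbon proves sensitive to a change of a single atom: amino in place of hydroxy, which turns carboxy into carbamoyl, gives a 7.3-fold lower number from compound 2 to compound 3 (0.86 log units; beyond the scatter) and so shows that the group's end alone can move this number well beyond the scatter. Measured against the (ethoxycarbonyl)carbamoyl group on the amine nitrogen, the (carbamoylcarbonyl)methyl group gives a 3.3-fold higher number from compound 1 to compound 3 (0.52 log units; beyond the scatter), a smaller step than a 24-fold higher number from compound 1 to compound 2 (1.38 log units; beyond the scatter) seen with the (carboxycarbonyl)methyl group, so the size of the gap from compound 1 depends on which group ends the chain. Nothing measured here accounts for these differences.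

Other groups on this carbonyl carbon, such as methoxy or methylamino, remain open, so it cannot yet be said whether the number tracks something particular to hydroxy or would shift with any replacement. As far as these compounds go, a longer chain on the amine nitrogen, carrying the same carbamoyl end, also remains open, which leaves unclear whether this step would keep its size elsewhere.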